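A few compounds are considered here, and "the series" means these few. Any claim that something is new, unique, unknown or untested is made for them only; others in the source may bear on it.

In a functional assay on HL-60 cells (Homo sapiens) for cytotoxicity, read by MTT assay, with a stated time of 48 h (a higher number here means a weaker inhibitor, a lower number a stronger inhibitor), compound 2 `Fc1cccc(-c2nc(Nc3ccccc3Cl)c3cc(F)ccc3n2)c1` gives > 50000 nM, which is a limit of the measurement rather than a number. Compound 1 `Fc1ccc(Nc2nc(-c3cccc(F)c3)nc3ccc(F)cc23)cc1` gives > 50000 nM in this assay, likewise a limit. The step that the two limits leave unreadable from compound 1 to compound 2 therefore cannot be read, as the limit of > 50000 nM in this assay, at which 2 of the 2 values shown sit, shows. Compound 3 `Fc1cccc(-c2nc(Nc3ccccc3Br)c3cc(F)ccc3n2)c1` differs from compound 2 by bromo in place of chloro on an aromatic carbon. For the measured compounds named here, no measured step bears on this change, and since both values sit at the limit, no step beyond the scatter is expected in this assay. Compound 3 is expected to give 70000 nM, between 20000 nM and 250000 nM, most likely again as a limit, a step that the limit leaves unreadable from compound 2 to compound 3 expected to stay within the scatter.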

Compound 3, half-maximal inhibitory concentration: > 50000 nM
Compound 3: no number, only a limit; the forecaster's own chance of this, stated with the estimate: 85%; the middle value lies beyond the limit too.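

Compound 1, compound 2 and compound 3 all stand at a limit in this assay, so no step among them can be read: the limit of > 50000 nM in this assay, at which 3 of the 3 values shown sit.

The compounds shown leave open whether any change to the shared core would give a readable value in this assay.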